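The source may report more compounds than this note shows. Statements on the series, on what has been measured and on what is new or still open speak of the compounds shown alone.

Compound 1 `COc1ccc(C2=NN(C3=NC(=O)/C(=C4\C(=O)Nc5ccc(Br)cc54)S3)C(c3ccc(Cl)cc3)C2)cc1` gives 340 nM in a functional assay on cells (Cancer cell lines, Homo sapiens) for cytotoxicity, read by sulforhodamine B assay, with a stated time of 48 h; a lower number here means a stronger inhibitor of growth, a higher number a weaker inhibitor of growth.
Compound 2 `COc1ccc(C2=NN(C3=NC(=O)/C(=C4\C(=O)Nc5ccc(Cl)cc54)S3)C(c3ccc(Cl)cc3)C2)cc1` gives 460 nM in this assay.
Compound 3 `CN(C)c1ccc(C2CC(c3ccccc3)=NN2C2=NC(=O)/C(=C3\C(=O)Nc4ccc(Br)cc43)S2)cc1` gives 540 nM in this assay.

Compound 1 and compound 2 differ in one place, (chloro in place of bromo on an aromatic carbon), and that change produced a 1.4-fold higher number from compound 1 to compound 2 (0.13 log units; within the scatter). Compound 3 carries a different core from compound 1; how the two cores differ is not broken down here, and the values of compound 3 and compound 1 lie within the scatter of each other.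

Compound 4 `CN(C)c1ccc(C2CC(c3ccccc3)=NN2C2=NC(=O)/C(=C3\C(=O)Nc4ccc(Cl)cc43)S2)cc1` has not yet been measured. It is compound 3 with chloro in place of bromo on an aromatic carbon, the same change as that from compound 1 to compound 2, at the same place. Because that earlier step was a 1.4-fold higher number from compound 1 to compound 2 (0.13 log units; within the scatter), a similarly small step, a 1.2-fold higher number from compound 3 to compound 4 (0.08 log units; within the scatter), is expected here, since nothing in the measured compounds suggests the core of compound 3 would respond differently. Compound 4 is therefore estimated at 650 nM, with a likely range from 350 nM to 1300 nM.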

Compound 4, concentration for total growth inhibition: 510 nM
Estimate against measurement, compound 4: 1.3-fold (0.11 log units) above, within the range that was stated.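

Replacing bromo with chloro on the core of compound 3 gives a 1.1-fold lower number from compound 3 to compound 4 (0.02 log units; within the scatter) in this assay, so this step is too small to read as a real change. Set beside the earlier step, the change behaves alike on the two cores as far as these data can tell: the same change on two cores in this assay, a 1.4-fold higher number (0.13 log units; within the scatter) from compound 1 to compound 2 and a 1.1-fold lower number (0.02 log units; within the scatter) from compound 3 to compound 4, 1.4-fold (0.16 log units) apart, within the scatter of two such steps. Among these compounds, this shows only that the swap stayed small on both cores; it does not show that bromo and chloro are interchangeable on other cores or in other assays.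

At this place the compounds shown carry only bromo or chloro. As far as these compounds go, what a much different group there, such as an amine or a carboxylic acid, would do remains open.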